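The compounds below may be only part of what the source reports. "The series", "measured", "known", "first", "only" and "open" are said of these compounds alone.

In an assay on isolated protein for inhibition of Intestinal-type alkaline phosphatase (Bos taurus), read by spectrophotometry, with stated times of 10 min and 30 min (a lower number here means a stronger inhibitor, a higher number a weaker inhibitor), compound 1 `CCOC1Oc2ccccc2C(=O)/C1=C\Nc1ccc(S(N)(=O)=O)cc1` gives 90600 nM, compound 2 `CCOC1Oc2ccc(Br)cc2C(=O)/C1=C\Nc1ccc(S(N)(=O)=O)cc1` gives 410 nM, and compound 3 `CCOC1Oc2ccccc2C(=O)/C1=C\Nc1cccc(S(N)(=O)=O)c1` gives 33500 nM. Compound 3 thus stands second highest of the three numbers; compound 1 sits nearest to it and somewhat higher, while compound 2 lies far lower. Compound 4 `CCOC1Oc2ccc(Br)cc2C(=O)/C1=C\Nc1cccc(S(N)(=O)=O)c1` differs from compound 3 by bromo in place of hydrogen on an aromatic carbon. Going by the values given here, one measured step bears directly on this change: a 220-fold lower number from compound 1 to compound 2 (2.34 log units; beyond the scatter), a move well beyond the scatter. A step of similar size and direction in this assay is therefore expected from compound 3 to compound 4, namely a 220-fold lower number from compound 3 to compound 4 (2.35 log units; beyond the scatter). Among the compounds with values here, compound 4 is accordingly estimated at 150 nM, with a range of 40 nM to 600 nM, the single precedent being the only basis.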

Compound 4, inhibition constant: 8700 nM
For compound 4 the middle estimate is 58-fold (1.76 log units) below the measured one, and the stated range ends below it.
By their numbers in this assay, from the lowest: compound 2; then compound 4; then compound 3; then compound 1.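

Bromo in place of hydrogen on an aromatic carbon still lowers the number on the core of compound 3 (a 3.9-fold lower number from compound 3 to compound 4 (0.59 log units; beyond the scatter)), so the direction of the change holds on both cores shown. Its size does not carry over from one core to the other: the same change on two cores in this assay, a 220-fold lower number (2.34 log units; beyond the scatter) from compound 1 to compound 2 and a 3.9-fold lower number (0.59 log units; beyond the scatter) from compound 3 to compound 4, 57-fold (1.76 log units) apart, beyond the scatter of two such steps.

As far as these compounds go, whether chloro, methyl or methoxy at this place would follow the bromo step on either core remains open. Two pairs also cannot show what in the cores sets the gap between the steps.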